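A Para-Fluoro Variant of an Inactive Triazole Sulfonate

The source may hold more compounds than are shown below. What is called first, only, known or untested is meant among the compounds shown, and "the series" means these compounds.

Compound 1, with the structure `Cc1ccc(S(=O)(=O)Oc2ccc3c(c2C)[C@H](Cn2cc(-c4ccccc4)nn2)[C@@]24CC(=O)[C@@](C)(CC[C@@H]32)C4)cc1`, was tested in a functional assay on HL-60 cells (Homo sapiens) for cytotoxicity, read by MTT assay, with a stated time of 4 days; on this read-out higher numbers stand for weaker inhibition and lower numbers for stronger inhibition. In this assay compound 1 gives > 20000 nM, which is a limit of the assay rather than a number, and the line the limit of > 20000 nM in this assay, at which 1 of the 2 values shown sits, records that one of the two values shown sits at it. Compound 2, with the structure `C=C1C(=O)[C@]23C[C@@]1(O)CC[C@H]2c1ccc(OS(=O)(=O)c2ccc(C)cc2)c(C)c1[C@@H]3Cn1cc(-c2ccc(F)cc2)nn1`, carries a different core and a fluorinated aryl group; in this assay compound 2 gives 1290 nM. For the measured compounds named here, no step between compound 1 and compound 2 is set out, so their two values are simply reported side by side.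

Compound 3, with the structure `Cc1ccc(S(=O)(=O)Oc2ccc3c(c2C)[C@H](Cn2cc(-c4ccc(F)cc4)nn2)[C@@]24CC(=O)[C@@](C)(CC[C@@H]32)C4)cc1`, has not yet been measured. It differs from compound 1 by a single change, (fluoro in place of hydrogen on an aromatic carbon), on an aromatic carbon of a six-membered aromatic ring of carbon only. Going by the values given here, with no measured step to anchor this change, its effect in this assay is expected to stay within the usual scatter, and compound 3 is expected to remain at or near the limit. The estimated step that the limit leaves unreadable from compound 1 to compound 3 is therefore small, and compound 3 is estimated at 25000 nM, within a range from 8000 nM to 80000 nM.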

Compound 3, half-maximal inhibitory concentration: > 20000 nM
Compound 3: no number, only a limit (the forecaster's own chance of this, stated with the estimate: 65%); the middle value lies beyond the limit too.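

In this assay compound 3 gives > 20000 nM which is a limit of the assay and not a number. For the compounds shown here, compound 1 stands at a limit as well, so no step from compound 1 to compound 3 can be read: the limit of > 20000 nM in this assay, at which 2 of the 3 values shown sit. The compounds shown leave open how far either compound lies beyond that limit, and so whether the change from phenyl to 4-fluorophenyl has any effect there.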